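This account rests on a few compounds, and the source may have more. Where it says the series, first, only, none or still open, it means among the compounds named here.

Series notes. The three measured compounds share one core: compound 1 `Cn1c2c(c3ccccc3c1=O)CCOc1ccccc1-2`, compound 2 `Cc1ccc2c3c(n(C)c(=O)c2c1)-c1ccccc1OCC3` and compound 3 `COc1cc2c3c(n(C)c(=O)c2cc1OC)-c1ccccc1OCC3`. Among the compounds with values here, in a functional assay on HL-60 cells (Homo sapiens) for cytotoxicity, read by sulforhodamine B assay (on this read-out lower numbers stand for stronger inhibition and higher numbers for weaker inhibition), compound 1 gives 37600 nM, compound 2 gives 14100 nM and compound 3 gives 34800 nM; compound 2 is the most potent of the three, the only measured step being a 2.7-fold lower number from compound 1 to compound 2 (0.43 log units; beyond the scatter), a methyl entering on an aromatic carbon. Compound 4 `COc1ccc(Cn2c3c(c4ccc(C)cc4c2=O)CCOc2ccccc2-3)cc1` carries 4-methoxyphenyl in place of hydrogen on a saturated chain carbon bound to an aromatic nitrogen. Within the data shown here, no measured pair differs at this carbon on the nitrogen, so nothing in the set speaks to the size or direction of this change; the expected step from compound 2 to compound 4 is therefore none beyond the scatter, a 1.0-fold lower number from compound 2 to compound 4 (0.00 log units; within the scatter), with wide uncertainty. Compound 4 is estimated at 14000 nM in this assay, within 4500 nM to 45000 nM.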

Compound 4, half-maximal inhibitory concentration: 4400 nM
Compound 4: middle estimate off by 3.2-fold (0.50 log units), on the high side; the whole stated range lies above it.
By their numbers in this assay, from the lowest: compound 4; then compound 2; then compounds 3 and 1 (each within the scatter of the next).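

In this assay, the saturated chain carbon bound to the aromatic nitrogen tolerates a large substituent: 4-methoxyphenyl in place of hydrogen gives a 3.2-fold lower number from compound 2 to compound 4 (0.51 log units; beyond the scatter). Within the data shown here, this is the first measured change at this position, and its direction is towards stronger inhibition, with a step of a size similar to that of the aromatic methyl. No measured evidence accounts for this step.

This remains a single change on the core of compound 2. From the compounds shown here alone, whether a plain benzyl, a longer alkyl chain or a chain ending in an amine would do the same remains open.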